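A Methyl on the Sulfur Chain, Among Limits

The source may report more compounds than this note shows. Statements on the series, on what has been measured and on what is new or still open speak of the compounds shown alone.

Compound 1 `CCC(C)Sc1nc(Cc2c(F)cccc2Cl)c(C)c(=O)[nH]1`: > 73000 nM
Compound 2 `CCC(C)Sc1nc(C(C)c2c(F)cccc2Cl)c(C)c(=O)[nH]1`: > 1500 nM
Compound 3 `CCC(c1nc(SC(C)C)[nH]c(=O)c1C)c1c(F)cccc1Cl`: > 3000 nM

All three results come from an ADME assay on MT4 cells (Homo sapiens) for activation, read by MTT assay (a higher number here means that more compound is tolerated, a lower number that less compound is tolerated), and none of them is a number. Compound 1 gives > 73000 nM, which is a limit. Compound 2 gives > 1500 nM, also a limit. Compound 3 gives > 3000 nM, again a limit, so its position in this assay is known only as a bound, like that of the other two.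

Compound 4 `CCC(C)Sc1nc(C(CC)c2c(F)cccc2Cl)c(C)c(=O)[nH]1` follows from compound 3 through (methyl in place of hydrogen on a saturated chain carbon, two bonds along the chain from a sulfur). In words, this is methyl in place of hydrogen on a saturated chain carbon, two bonds along the chain from a sulfur, turning isopropylsulfanyl into (sec-butyl)sulfanyl.

Within the data shown here, only one measured step comes close, a step that the two limits leave unreadable from compound 1 to compound 2. It also brings in a methyl, but on a saturated chain carbon bound to two aromatic carbons, and it has no readable size. It therefore offers no ground for predicting a shift in either direction, and compound 4 may well be reported as a limit too.

The expected outcome is a number no higher from compound 3 to compound 4 (the limit leaves the size open), with no change beyond the scatter anticipated. For compound 4 the estimated value is 3000 nM, with an expected range from 1000 nM to 40000 nM.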

Compound 4, half-maximal cytotoxic concentration: > 3000 nM
Compound 4: no number, only a limit; the forecaster's own chance of this, stated with the estimate: 75%; the middle value lies on the limit itself.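

In this assay compound 4 gives > 3000 nM, which is a limit and not a number. The steps to compound 4 from compound 1, compound 2 and compound 3 cannot be read, as all four results are limits. The compounds shown leave open where any of the four truly stands and whether the added methyl shifts the value at all.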